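A few compounds are considered here, and "the series" means these few. Any claim that something is new, unique, unknown or untested is made for them only; others in the source may bear on it.

Compound 3 `O=S(=O)(Nc1ccc2oc(-c3ccccc3)nc2c1)c1ccc(O)cc1` has been tested in an ADME assay on HEK293 cells (Homo sapiens) for cytotoxicity, read by resazurin assay, with a stated time of 48 h (a higher number here means that more compound is tolerated, a lower number that less compound is tolerated), where compound 3 gives > 100000 nM, which is a limit of the assay rather than a number. Compound 1 `O=S(=O)(Nc1ccc(-c2nc3ccccc3o2)cc1)c1cccc(Cl)c1` likewise gives > 100000 nM, again a limit. Compound 2 `O=S(=O)(Nc1ccc(-c2nc3ccccc3o2)cc1)c1ccccc1O` gives > 100000 nM, also a limit. The step from compound 1 to compound 2 is a step that the two limits leave unreadable from compound 1 to compound 2, which cannot be read because of the limit of > 100000 nM in this assay, at which 3 of the 3 values shown sit. Compound 4 `CCc1ccc(S(=O)(=O)Nc2ccc3oc(-c4ccccc4)nc3c2)cc1` differs from compound 3 by ethyl in place of hydroxy on an aromatic carbon. For the measured compounds named here, no measured step matches this change, and none of the measured values is an actual number, so nothing here points to a shift beyond the scatter. Compound 4 is therefore expected to sit at the same limit, a step of roughly a number no higher from compound 3 to compound 4 (the limit leaves the size open), giving an estimate of 100000 nM with a range from 40000 nM to 250000 nM.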

Compound 4, half-maximal cytotoxic concentration: 81000 nM
For compound 4 the middle estimate is 1.2-fold (0.09 log units) above the measured one; low and high end bracket the measured number.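

For the compounds shown here, with 4-ethylphenyl in place of 4-hydroxyphenyl, compound 4 gives 81000 nM in this assay, the first actual number in this set. The earlier compounds shown here gave only limits. The change amounts to an at least 1.2-fold lower number from compound 3 to compound 4 (0.09 log units; that floor lies within the scatter). So hydroxy can give way to ethyl here with no shift shown beyond the scatter, though the true size of the step stays unknown because one end of it is a limit: the limit of > 100000 nM in this assay, at which 3 of the 4 values shown sit.

Going by these compounds, whether an amine, a carboxylic acid or a chain longer than ethyl at this position would give a clearly different number remains open.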